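From 3-hydroxyphenyl to 4-chlorophenyl on the shared core

This account rests on a few compounds, and the source may have more. Where it says the series, first, only, none or still open, it means among the compounds named here.

Compound 1 `COc1cc(-n2cnc3ccc(-c4ccc([N+](=O)[O-])cc4)cc32)cc(OC)c1OC`: 79 nM
Compound 2 `COc1cc(-n2cnc3ccc(-c4cccc(O)c4)cc32)cc(OC)c1OC`: 53 nM

Both values come from a functional assay on SGC-7901 cells (Homo sapiens) for antiproliferative activity, read by MTT assay, with a stated time of 72 h; on this read-out lower numbers stand for stronger inhibition and higher numbers for weaker inhibition. Among the measured compounds shown here, the series so far holds one measured step, a 1.5-fold lower number from compound 1 to compound 2 (0.17 log units; within the scatter). For the measured compounds named here, on these numbers compound 2 does not stand apart from the only other measured compound.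

Next is compound 3 `COc1cc(-n2cnc3ccc(-c4ccc(Cl)cc4)cc32)cc(OC)c1OC`, with 4-chlorophenyl in place of 3-hydroxyphenyl on an aromatic carbon. In words, this puts 4-chlorophenyl in place of 3-hydroxyphenyl on an aromatic carbon. Going by the values given here, the one measured step also exchanged the aryl group on that carbon, and it stayed within the scatter. Among the compounds with values here, no compound with a 4-chlorophenyl group has been measured yet, so a step beyond the scatter in this assay is not expected. The expected change is a 1.3-fold higher number from compound 2 to compound 3 (0.12 log units; within the scatter). For compound 3 the estimate is 70 nM, with an expected range of 25 nM to 200 nM.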

Compound 3, half-maximal inhibitory concentration: 1270 nM
The estimate for compound 3 lay 18-fold (1.26 log units) below the measured number; the measured number lies above the stated range.
By their numbers in this assay, from the lowest: compounds 2 and 1 (each within the scatter of the next); then compound 3.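

In this assay this position proves sensitive to the choice of aryl group: the earlier exchange stayed within the scatter, whereas 4-chlorophenyl in place of 3-hydroxyphenyl gives a 24-fold higher number from compound 2 to compound 3 (1.38 log units; beyond the scatter) in one large step. The change of chloro for nitro gives a 16-fold higher number from compound 1 to compound 3 (1.21 log units; beyond the scatter) and shows that the outcome depends on the group carried by the phenyl ring, since 4-nitrophenyl and 4-chlorophenyl differ only there. Nothing available explains why chloro gives so much higher a number than either nitro or the 3-hydroxyphenyl group.

From the compounds shown here alone, whether the change follows chloro itself or its placement stays open, and 3-chlorophenyl on the shared core would separate the two. Going by these compounds, it also stays open how 4-hydroxyphenyl, 4-aminophenyl or 4-carboxyphenyl would compare with these three compounds.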